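Adding a methyl to the nitrogen of compound 1

The source may hold more compounds than are shown below. What is called first, only, known or untested is meant among the compounds shown, and "the series" means these compounds.

Among the measured compounds shown here, in a functional assay on the whole organism with Mus musculus as the target, with a stated time of 0.5 h (on this read-out lower numbers stand for an effect already at smaller amounts and higher numbers for an effect only at larger amounts of compound), compound 1 `CC[C@]1(c2ccccc2)OC(=O)NC1=O` gives 108 mg/kg as the higher of the two exact numbers so far. In this assay compound 3 `O=C1O[C@@]2(c3ccccc3)CCCCCN1C2=O` gives 50 mg/kg and so acts at a smaller dose than compound 1, by more than the scatter. Compound 2 `O=C1O[C@]2(c3ccccc3)CCCCCN1C2=O` has only a limit (< 400 mg/kg).

Compound 4 `CC[C@]1(c2ccccc2)OC(=O)N(C)C1=O` differs from compound 1 by one change (methyl in place of hydrogen on an amide-type nitrogen in a ring): methyl in place of hydrogen on an amide-type nitrogen in a ring. For the measured compounds named here, the only measured step (a step that the limit leaves unreadable from compound 2 to compound 3) reflects the fact that compounds 2 and 3 differ only in the configuration as drawn and has no readable size, so it offers no guide to a methyl. In this assay no shift beyond the scatter is therefore expected (a 1.1-fold lower number from compound 1 to compound 4 (0.03 log units; within the scatter)). Compound 4 is expected to give 100 mg/kg (estimated range 40 mg/kg to 250 mg/kg).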

Compound 4, dose for half-maximal effect: 69 mg/kg
Compound 4: the middle estimate sits 1.4-fold (0.16 log units) above what was measured; the measured number falls inside the stated range.
By their numbers in this assay, from the lowest: compounds 3, 4 and 1 (each within the scatter of the next, the first and the last beyond it).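

In this assay, among the compounds shown here, methyl in place of hydrogen on the amide-type nitrogen gives a 1.6-fold lower number from compound 1 to compound 4 (0.19 log units; within the scatter) and so gives the first readable step at this position. The effect in the whole animal therefore does not depend on the amide hydrogen, and this nitrogen accepts a methyl without a shift beyond the scatter. Nothing at hand bears on a cause for this step.

On these data alone, whether a longer chain, an amine or a carboxylic acid on this nitrogen would keep the effect stays open. As far as these compounds go, the opposite configuration of compound 1 and compound 4 at the ring carbon also remains open.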